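Replacing an Aryl Group with an Arylamino on a Carbonyl

A few compounds are considered here, and "the series" means these few. Any claim that something is new, unique, unknown or untested is made for them only; others in the source may bear on it.

Compound 1 `COc1cc(-c2nn(-c3cccc(NC(=O)c4ccc(Cl)c(C(F)(F)F)c4)c3)cc2-c2ccncc2)ccc1Cl` was tested in a functional assay on OVCAR-5 cells (Homo sapiens) for inhibition, read by sulforhodamine B assay, with a stated time of 48 h; a higher number here means a weaker inhibitor of growth, a lower number a stronger inhibitor of growth. In this assay compound 1 returns only a limit of the assay, > 32500 nM, so it has no number of its own. It therefore stands at the limit of > 32500 nM in this assay, at which 1 of the 2 values shown sits, and nothing more precise can be said of it. For the measured compounds named here, compound 2 `O=C(Nc1cccc(-n2cc(-c3ccncc3)c(-c3ccc(Cl)c(O)c3)n2)c1)Nc1cc(C(F)(F)F)cc(C(F)(F)F)c1` is the only other measured compound; in this assay compound 2 gives 875 nM. Going by the values given here, no pair of measured compounds differs in just one place, so no measured step is available, and the two values can only be taken as they stand.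

Compound 3 `COc1cc(-c2nn(-c3cccc(NC(=O)Nc4cccc(C(F)(F)F)c4)c3)cc2-c2ccncc2)ccc1Cl` has not yet been measured. It differs from compound 1 in one place: (3-(trifluoromethyl)phenyl)amino in place of 4-chloro-3-(trifluoromethyl)phenyl on a carbonyl carbon. Since compound 2 reaches 875 nM, a number well within the range of this assay, a compound of this general build can be measured. The step expected in this assay is an at least 10-fold lower number from compound 1 to compound 3 (1.03 log units; beyond the scatter), toward stronger growth inhibition and beyond the usual scatter. Compound 3 is therefore estimated at 3000 nM, within a range from 600 nM to 20000 nM.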

Compound 3, concentration for 50% growth inhibition: 1270 nM
For compound 3 the middle estimate is 2.4-fold (0.37 log units) above the measured one, and the stated range covers the measured number.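

At this carbonyl carbon, the swap gives an at least 25-fold lower number from compound 1 to compound 3 (1.40 log units; beyond the scatter) in this assay, so this position responds strongly to what is attached to the carbonyl. Going by these compounds, the true size of the step remains unknown because compound 1 has only a limit of the assay and not a number: the limit of > 32500 nM in this assay, at which 1 of the 3 values shown sits. The swap is also more than one simple change: the entering group brings an amino nitrogen with a hydrogen-bond donor, which the leaving group lacks, and the chlorine on the aromatic ring is lost.

The nitrogen and the chlorine change together here, so the compounds shown cannot say which of the two differences carries the step, or whether both contribute. A (4-chloro-3-(trifluoromethyl)phenyl)amino group on the same carbonyl carbon would keep the chlorine alongside the new nitrogen and so separate the two, while a methyl(3-(trifluoromethyl)phenyl)amino group, with a methyl in place of the hydrogen on that nitrogen, would test whether that hydrogen matters.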